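This account rests on a few compounds, and the source may have more. Where it says the series, first, only, none or still open, it means among the compounds named here.

Compound 1 `Cc1cccc(C)c1NC(=O)/C=C/C(=O)N1C/C(=C\c2ccccc2)C(=O)/C(=C/c2ccccc2)C1` is the weakest of the three measured compounds in a functional assay on CCRF-CEM cells (Homo sapiens) for cytotoxicity (on this read-out lower numbers stand for stronger inhibition and higher numbers for weaker inhibition), where compound 1 gives 7400 nM. The other two share a different core: compound 2 `Cc1ccc(NC(=O)/C=C/C(=O)N2C/C(=C\c3ccc([N+](=O)[O-])cc3)C(=O)/C(=C/c3ccc([N+](=O)[O-])cc3)C2)cc1C` gives 700 nM and compound 3 `Cc1ccc(NC(=O)/C=C/C(=O)N2C/C(=C\c3ccc([N+](=O)[O-])cc3)C(=O)/C(=C/c3ccc([N+](=O)[O-])cc3)C2)cc1` gives 890 nM, each clearly stronger than compound 1, with compound 3 the nearer of the two.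

Compound 4 `O=C(/C=C/C(=O)N1C/C(=C\c2ccccc2)C(=O)/C(=C/c2ccccc2)C1)Nc1ccc(Cl)cc1` keeps the core of compound 1 and changes only the aromatic ring on the amide-type nitrogen: 4-chlorophenyl in place of 2,6-dimethylphenyl on an amide-type nitrogen. The (2,6-dimethylphenyl)amino group becomes a (4-chlorophenyl)amino group.

Among the compounds with values here, the one measured step that touches this part of the molecule is a 1.3-fold higher number from compound 2 to compound 3 (0.10 log units; within the scatter), where a methyl on an aromatic carbon was replaced by hydrogen and the number barely moved. Within the data shown here, that step concerns a smaller change than the one from compound 1 to compound 4, where two methyl groups are removed and a chlorine enters at a different position of the ring, so the guidance is limited. Among the measured compounds shown here, there is no measured step from compound 1 to a compound with a different ring on this nitrogen. On that basis the expectation is a step of a 1.2-fold lower number from compound 1 to compound 4 (0.09 log units; within the scatter) in this assay, small and not clearly beyond the scatter. Compound 4 is therefore estimated at 6000 nM, with a range from 2500 nM to 15000 nM.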

Compound 4, half-maximal inhibitory concentration: 840 nM
The estimate for compound 4 lay 7.1-fold (0.85 log units) above the measured number; the measured number lies below the stated range.
By their numbers in this assay, from the lowest: compounds 2, 4 and 3 (each within the scatter of the next); then compound 1.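

In this assay, putting 4-chlorophenyl in place of 2,6-dimethylphenyl on the amide-type nitrogen brings an 8.8-fold lower number from compound 1 to compound 4 (0.94 log units; beyond the scatter) on the core of compound 1, so the ring at this position can shift the number beyond the scatter. Within the data shown here, the only earlier step at this ring, a 1.3-fold higher number from compound 2 to compound 3 (0.10 log units; within the scatter) on a different core, involved a single methyl and stayed within the scatter, so it gave no sign that this ring could matter to this extent. No measurement shown here bears on what lies behind the larger step.

The change removes two methyl groups and adds a chlorine at once, so the compounds shown leave open which part carries the step; a plain phenyl, a 2,6-dichlorophenyl or a 4-methylphenyl on the same nitrogen would help pull the two apart. Also open, going by these compounds, is whether a ring carrying an amine or a carboxylic acid would be tolerated here, and whether the same swap would give a step of similar size on the core shared by compound 2 and compound 3.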